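Diaryl urea series on the chloropyrazine benzylamine core

This account rests on a few compounds, and the source may have more. Where it says the series, first, only, none or still open, it means among the compounds named here.

Measured:
compound 1 `CC(C)(C)c1ccc(NC(=O)Nc2cccc(CNc3nccnc3Cl)c2)cc1` — 6010 nM
compound 2 `O=C(Nc1cccc(CNc2nccnc2Cl)c1)Nc1ccc(Cl)c(Cl)c1` — 5210 nM

Two compounds of the series have been run in a functional assay on T-24 cells (Homo sapiens) for antiproliferative activity, read by MTT assay, with a stated time of 48 h; a higher number here means a weaker inhibitor, a lower number a stronger inhibitor. Compound 2 gives 5210 nM, the lower of the two numbers; compound 1 gives 6010 nM, and the gap between the two lies within the scatter, so no order can be read between them. Going by the values given here, both carry the same core, and the only variation so far is the aryl group on the amide-type nitrogen of the urea.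

Among the compounds with values here, compound 3 `CN(C)c1ccc(NC(=O)Nc2cccc(CNc3nccnc3Cl)c2)cc1` continues this variation. 4-(dimethylamino)phenyl in place of 3,4-dichlorophenyl on an amide-type nitrogen No measured step of this kind exists, so there is nothing to say how the replacement of one aryl group by another moves the number. On the present evidence the expected step from compound 2 to compound 3 in this assay is a 1.2-fold higher number from compound 2 to compound 3 (0.10 log units; within the scatter), that is, none beyond the scatter. Compound 3 is therefore estimated at 6500 nM, with a range of 2500 nM to 17000 nM.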

Compound 3, half-maximal inhibitory concentration: 20200 nM
Estimate against measurement, compound 3: 3.1-fold (0.49 log units) below; the measured number lies above the stated range.
By their numbers in this assay, from the lowest: compounds 2 and 1 (each within the scatter of the next); then compound 3.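

In this assay the aryl group on the amide-type nitrogen now proves able to move the number: 4-(dimethylamino)phenyl in place of 3,4-dichlorophenyl gives a 3.9-fold higher number from compound 2 to compound 3 (0.59 log units; beyond the scatter) as a step beyond the scatter, which the pair of compound 1 and compound 2 could not show. Dimethylamino in place of tert-butyl on an aromatic carbon points the same way, with a 3.4-fold higher number from compound 1 to compound 3 (0.53 log units; beyond the scatter) in the same assay, so compound 3 stands apart from both earlier compounds, while those two remain within the scatter of each other. Nothing measured here bears on why the number rises with this change, and the step records only the size and direction of the shift.

Going by these compounds, whether the shift belongs to dimethylamino in particular or would also appear with a primary amine, a methoxy group or a morpholine on the same aromatic carbon remains open. Also open, on these data alone, is whether an unsubstituted phenyl or a carboxylic acid on that ring would give a number close to compound 1 and compound 2 or one close to compound 3.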